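Ring methyl next to the nitrogen: compound 3 to compound 4

The compounds below may be only part of what the source reports. "The series", "measured", "known", "first", "only" and "open" are said of these compounds alone.

Measured compounds:
compound 1 `Cc1ccnc(/C(N)=N/NC(=S)N2CCSCC2)c1`: 79.6%
compound 2 `Cc1ccnc(/C(N)=N/NC(=S)N2CCCCCC2)c1`: 71%
compound 3 `N/C(=N\NC(=S)N1CCCCCC1)c1ccccn1`: 77.5%

In a functional assay on A-431 cells (Homo sapiens) for cytotoxicity, read by MTT assay, with a stated time of 72 h, tested at 100 uM (on this read-out higher numbers stand for more inhibition of growth at the one concentration tested and lower numbers for less inhibition of growth), compound 3 gives 77.5%, the second highest of the three numbers; the nearest is compound 1 and the furthest compound 2, both within the scatter. Compound 4 `Cc1cccc(/C(N)=N/NC(=S)N2CCCCCC2)n1` differs from compound 3 by methyl in place of hydrogen on an aromatic carbon. For the measured compounds named here, the only measured step that bears on this is the reverse move on the same ring, a number 6.5 percentage points higher from compound 2 to compound 3 (within the scatter), which stayed within the scatter. A methyl on this ring has so far made no difference beyond the scatter, so none is expected here either. Compound 4 is therefore estimated at 75%, range 62% to 86%, which means an expected step of a number 2.5 percentage points lower from compound 3 to compound 4 (within the scatter).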

Compound 4, percent growth inhibition at one concentration: 76.7%
Compound 4: middle estimate off by 1.7 percentage points, on the low side, within the range that was stated.
By their numbers in this assay, from the lowest: compounds 2, 4, 3 and 1 (each within the scatter of the next).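

In this assay, methyl in place of hydrogen next to the ring nitrogen gives a number 0.8 percentage points lower from compound 3 to compound 4 (within the scatter). Together with a number 6.5 percentage points higher from compound 2 to compound 3 (within the scatter), this makes two ring positions where the change between hydrogen and methyl stays within the scatter, so neither position shows a measurable effect of methyl on this read-out. Nothing measured here explains this result.

Open, as far as these compounds go, is whether a larger or charged group at this position, such as an isopropyl, an amine or a carboxylic acid, would move the number beyond the scatter. Single-concentration values also leave open whether compound 3 and compound 4 would separate at lower concentrations.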